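The compounds below may be only part of what the source reports. "The series", "measured", "known", "first", "only" and "open" are said of these compounds alone.

Compound 1 `CCC(C(=O)NCc1ccc(C(F)(F)F)nc1N1CCC(C)CC1)c1ccc(NS(C)(=O)=O)c(F)c1` is measured in an assay on CHO cells for antagonist activity at transient receptor potential cation channel subfamily V member 1 (Homo sapiens), read by FLIPR (a higher number here means a weaker inhibitor, a lower number a stronger inhibitor), where compound 1 gives 1.6 nM. Two companions share its core. Going by the values given here, compound 3 `Cc1ccc(C(C(=O)NCc2ccc(C(F)(F)F)nc2N2CCC(C)CC2)c2ccc(NS(C)(=O)=O)c(F)c2)cc1` carries 4-methylphenyl in place of ethyl on the saturated chain carbon bound to an aromatic carbon and a carbonyl carbon, and in this assay compound 3 gives 1.1 nM; the step of a 1.5-fold lower number from compound 1 to compound 3 (0.16 log units; within the scatter) is the only single-point change with numbers on both sides. Compound 2 `Cc1ccccc1C(C(=O)NCc1ccc(C(F)(F)F)nc1SC1CCCCC1)c1ccc(NS(C)(=O)=O)c(F)c1` is recorded in this assay only as "active" (no number reported), without a figure. Among the two numbered entries compound 1 has the higher number, with compound 3 nearest and within the scatter, so no order between them can be read.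

Compound 4 `CC1CCN(c2nc(C(F)(F)F)ccc2CNC(=O)C(Cc2ccccc2)c2ccc(NS(C)(=O)=O)c(F)c2)CC1` differs from compound 1 as follows: phenyl in place of methyl on a saturated chain carbon, two bonds along the chain from an aromatic carbon and a carbonyl carbon. Among the compounds with values here, the one step that bears on this, from compound 1 to compound 3, also enlarged the group on that chain and stayed within the scatter, though it acted one bond nearer the carbonyl carbon. Within the data shown here, no measured pair tells what a benzyl in place of an ethyl at this spot does. Compound 4 is therefore expected to show a step of a 1.1-fold lower number from compound 1 to compound 4 (0.03 log units; within the scatter), which is no change beyond the scatter. Compound 4 is estimated at 1.5 nM, within a range from 0.5 nM to 5 nM.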

Compound 4, inhibition constant: 65.9 nM
Estimate against measurement, compound 4: 44-fold (1.64 log units) below; measured number outside the range, above it.
By their numbers in this assay, from the lowest: compounds 3 and 1 (each within the scatter of the next); then compound 4.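

In this assay, the group on this chain carbon now proves able to matter: going from ethyl to benzyl gives a 41-fold higher number from compound 1 to compound 4 (1.61 log units; beyond the scatter), a large loss that the earlier pair, with its step within the scatter, gave no sign of. The ring itself does not carry the loss, since 4-methylphenyl on the saturated chain carbon bound to an aromatic carbon and a carbonyl carbon sits within the scatter of ethyl, whereas moving to benzyl, with its phenyl two bonds along the chain, gives a 60-fold higher number from compound 3 to compound 4 (1.78 log units; beyond the scatter). Nothing shown here offers a measured reason for this loss.

The compounds shown leave open whether the loss belongs to the phenyl ring at that distance or to any extension of the chain, a question on which a propyl group or a cyclohexylmethyl group in place of benzyl would bear. They also leave open whether the same change would cost as much alongside the cyclohexylthio group of compound 2, which has no number in this assay.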